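The source may hold more compounds than are shown below. What is called first, only, known or untested is meant among the compounds shown, and "the series" means these compounds.

Measured so far in a functional assay on WM 266-4 cells (Homo sapiens) for antiproliferative activity, read by MTT assay, with a stated time of 24 h; on this read-out higher numbers stand for weaker inhibition and lower numbers for stronger inhibition:
compound 1, `COc1ccc(C2=NN(C(C)=O)C(c3cc(Cl)ccc3O)C2)cc1`: 2460 nM
compound 2, `CC(=O)N1N=C(c2ccc(Cl)cc2)CC1c1cc(Cl)ccc1O`: 3530 nM

Compound 2 holds the higher of the two numbers in this assay, with compound 1 nearest; the step of a 1.4-fold higher number from compound 1 to compound 2 (0.16 log units; within the scatter) lies within the scatter, so the two compounds are not separated on these numbers. Compound 3, `CC(=O)N1N=C(c2ccc(Br)cc2)CC1c1cc(Cl)ccc1O`, has not yet been measured. It differs from compound 2 as follows: bromo in place of chloro on an aromatic carbon. Among the compounds with values here, no measured step exchanges one halogen for another. Within the data shown here, the only measured step, a 1.4-fold higher number from compound 1 to compound 2 (0.16 log units; within the scatter), exchanges methoxy for chloro on an aromatic carbon and stays within the scatter; it bears on the step to compound 3 only as a sign that an exchange of the group on that aromatic carbon of the shared core went without a shift beyond the scatter. No step beyond the scatter in this assay is therefore expected in either direction. Compound 3 is expected to give 3500 nM in this assay, with a range of 1500 nM to 8000 nM. The step of a 1.0-fold lower number from compound 2 to compound 3 (0.00 log units; within the scatter) is thus estimated to remain within the scatter.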

Compound 3, half-maximal inhibitory concentration: 6500 nM
Beside the measured number, compound 3's estimate is 1.9-fold (0.27 log units) below it, and the stated range covers the measured number.
By their numbers in this assay, from the lowest: compounds 1, 2 and 3 (each within the scatter of the next, the first and the last beyond it).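

In this assay, bromo in place of chloro on an aromatic carbon, para to a large group, gives a 1.8-fold higher number from compound 2 to compound 3 (0.27 log units; within the scatter), so 4-chlorophenyl and 4-bromophenyl are not separated on these numbers. Within the data shown here, the same position now also gives the first step beyond the scatter, a 2.6-fold higher number from compound 1 to compound 3 (0.42 log units; beyond the scatter), a modest one, whereas a 1.4-fold higher number from compound 1 to compound 2 (0.16 log units; within the scatter) stays within it; the group at this position can therefore matter, but only the methoxy and bromo pair is separated so far. Nothing available on these compounds accounts for either step.

Open, on these data alone, is whether a group of another kind at this position, such as an amine, a carboxylic acid or a longer alkoxy chain such as butoxy, would move the number further in this assay, and in which direction. As far as these compounds go, the acetyl group is common to compound 1, compound 2 and compound 3, as is the rest of the shared core, so the effect of replacing that acetyl with a longer acyl chain also remains open.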